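Chloro for methyl next to a diacetylamino group

This account rests on a few compounds, and the source may have more. Where it says the series, first, only, none or still open, it means among the compounds named here.

In a functional assay on MCF7 cells (Homo sapiens) for antiproliferative activity (a higher number here means a weaker inhibitor, a lower number a stronger inhibitor), compound 1 `Cc1cc(-c2nc3ccccc3s2)ccc1N` gives < 1 nM, a limit of the assay.
In this assay compound 2 `Nc1ccc(-c2nc3ccccc3s2)cc1Cl` gives < 1 nM, a limit of the assay.
In this assay compound 3 `CC(=O)N(C(C)=O)c1ccc(-c2nc3ccccc3s2)cc1C` gives > 10000 nM, a limit of the assay.

The change chloro in place of methyl on an aromatic carbon gave a step that the two limits leave unreadable from compound 1 to compound 2, since both values sit at the limit of < 1 nM in this assay, at which 2 of the 3 values shown sit. The two cores differ by diacetylamino in place of amino on an aromatic carbon, which gave an at least 10000-fold higher number from compound 1 to compound 3 (4.00 log units; beyond the scatter), ending at the limit of > 10000 nM in this assay, at which 1 of the 3 values shown sits. Compound 4 `CC(=O)N(C(C)=O)c1ccc(-c2nc3ccccc3s2)cc1Cl` carries the same kind of change, (chloro in place of methyl on an aromatic carbon), but here the place is ortho to a diacetylamino group rather than ortho to an amino group. The step in this assay from compound 3 is expected to be a step that the limit leaves unreadable from compound 3 to compound 4, resting on compound 3 sitting at the limit of > 10000 nM in this assay, at which 1 of the 3 values shown sits, and on the earlier step being unreadable. Compound 4 is therefore estimated at 20000 nM, between 8000 nM and 60000 nM.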

Compound 4, half-maximal inhibitory concentration: > 10000 nM
Compound 4: a limit, no number; the forecaster's own chance of this, stated with the estimate: 85%; the middle value does not contradict the limit.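

In this assay, putting diacetylamino in place of amino gave an at least 10000-fold higher number from compound 2 to compound 4 (4.00 log units; beyond the scatter), so the large step seen on the core of compound 1 returns on the core of compound 2: the same change on two cores in this assay, an at least 10000-fold higher number (4.00 log units; beyond the scatter) from compound 1 to compound 3 and an at least 10000-fold higher number (4.00 log units; beyond the scatter) from compound 2 to compound 4; the limit leaves it open whether they differ

Compound 4 gives > 10000 nM, which is a limit of the assay: the limit of > 10000 nM in this assay, at which 2 of the 4 values shown sit.

The steps of chloro in place of methyl cannot be read on either core, so the pair shows that the large step recurs, but not that its size is the same on both cores, nor whether chloro and methyl differ at all.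

The compounds shown leave open how much of the step a single acetyl group would give, as in an acetylamino group in place of the amino group on either core. They also leave open whether a fluoro or methoxy group in place of the chloro would leave the amino compounds at their limit.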